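The compounds below may be only part of what the source reports. "The series", "measured", "known", "first", "only" and "open" are said of these compounds alone.

Of the compounds shown here, two have numbers so far. Compound 1 `COc1ccc(-c2cc(C(=O)N/N=C/c3ccccc3O)n(Cc3ccc(Cl)nc3)n2)cc1` gives 8120 nM in a functional assay on A549 cells (Homo sapiens) for cytotoxicity, read by MTT assay, with a stated time of 48 h; on this read-out higher numbers stand for weaker inhibition and lower numbers for stronger inhibition. Among the measured compounds shown here, compound 2 `CC(C)(C)c1ccc(Cn2nc(-c3ccc(Cl)cc3)cc2C(=O)N/N=C/c2ccccc2O)cc1` gives 3390 nM in this assay and stands lowest of the two, with compound 1 carrying the higher number by a gap beyond the scatter; the two differ in more than one place, so no single step between them can be read. Compound 3 `COc1ccc(-c2cc(C(=O)N/N=C/c3ccccc3O)n(Cc3ccc(C(C)(C)C)cc3)n2)cc1` is not yet measured. It is reached from compound 2 by a single change, methoxy in place of chloro on an aromatic carbon. For the measured compounds named here, no measured pair shows this change alone, so its effect cannot be read from the numbers at hand. The step from compound 2 to compound 3 is expected to be small, most likely none beyond the scatter, written as a 1.3-fold higher number from compound 2 to compound 3 (0.12 log units; within the scatter). Compound 3 is estimated at 4500 nM in this assay, within a range from 2000 nM to 10000 nM.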

Compound 3, half-maximal inhibitory concentration: 4890 nM
Estimate against measurement, compound 3: 1.1-fold (0.04 log units) below, within the range that was stated.
By their numbers in this assay, from the lowest: compounds 2, 3 and 1 (each within the scatter of the next, the first and the last beyond it).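

In this assay, 4-methoxyphenyl in place of 4-chlorophenyl gives a 1.4-fold higher number from compound 2 to compound 3 (0.16 log units; within the scatter), so at this aromatic carbon, para to a large group, methoxy and chloro cannot be told apart by their numbers. Compound 3 also gives the series a second single change: 4-(tert-butyl)phenyl in place of 6-chloropyridin-3-yl on the saturated chain carbon gives a 1.7-fold lower number from compound 1 to compound 3 (0.22 log units; within the scatter), and this exchange likewise shows no effect that can be separated from the scatter. No evidence is at hand that bears on these two results.

On these data alone, whether an amine or a carboxylic acid at the aromatic carbon that carries chloro or methoxy would give a step beyond the scatter remains open. The core shared by all three compounds stays constant, so the compounds shown say nothing about changes there.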